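A few compounds are considered here, and "the series" means these few. Any claim that something is new, unique, unknown or untested is made for them only; others in the source may bear on it.

Values in a functional assay on SNB-19 cells (Homo sapiens) for inhibition, read by sulforhodamine B assay, with a stated time of 48 h; on this read-out lower numbers stand for higher toxicity in this test and higher numbers for lower toxicity in this test:

Compound 1, `COc1ccc(CNc2nc3cc(N)cc(N)c3nc2-c2ccccc2)cc1OC`, gives < 100000 nM, a limit of the assay and not a number.
Compound 2, `Nc1cc(N)c2nc(-c3ccccc3)c(NCc3ccc(F)cc3)nc2c1`, gives 52500 nM.
Compound 3, `COc1ccc(Sc2nc3cc(N)cc(N)c3nc2-c2ccccc2)cc1`, gives < 100000 nM, again a limit of the assay.

Compound 3 therefore stands only at a limit; this is the limit of < 100000 nM in this assay, at which 2 of the 3 values shown sit, so its place relative to the other two cannot be read. The change to compound 4, `Nc1cc(N)c2nc(-c3ccccc3)c(Oc3ccc(F)cc3)nc2c1`, is 4-fluorophenoxy in place of (4-methoxyphenyl)sulfanyl on an aromatic carbon. Among the compounds with values here, the two measured steps that touch this part of the core, a step that the limit leaves unreadable from compound 1 to compound 2 and a step that the limit leaves unreadable from compound 2 to compound 3, are both left unreadable by the limit, so no measured step gives a direction or a size for the exchange of the (4-methoxyphenyl)sulfanyl group for 4-fluorophenoxy. Within the data shown here, the only number, that of compound 2, sits close to the limit itself, and all three values together show weak toxicity in this assay. Compound 4 is therefore expected to stay in the same weak region, with the step that the limit leaves unreadable from compound 3 to compound 4 estimated as none beyond the scatter. The estimate for compound 4 in this assay is 70000 nM, between 30000 nM and 150000 nM.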

Compound 4, concentration lethal to 50% of the cells: 66100 nM
For compound 4 the middle estimate is 1.1-fold (0.02 log units) above the measured one, within the range that was stated.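

In this assay compound 4 gives 66100 nM, a second true number for a group on this aromatic carbon next to the ring nitrogen. Within the data shown here, the one readable step is a 1.3-fold higher number from compound 2 to compound 4 (0.10 log units; within the scatter), with 4-fluorophenoxy in place of (4-fluorobenzyl)amino, so these two groups cannot be told apart in this assay. All other steps cannot be read, because they touch a compound that stands at a limit: the limit of < 100000 nM in this assay, at which 2 of the 4 values shown sit.

Going by these compounds, it remains open how 4-fluorophenoxy compares with (4-methoxyphenyl)sulfanyl, and whether any group at this position can move the value beyond the scatter. A carboxylic acid, a primary amine or a longer chain ending in an amine at this carbon would test that, as would an amine in place of the phenyl group on the neighbouring ring position of the shared core.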